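Adding a Methoxy to the Phenyl of Compound 3

The compounds below may be only part of what the source reports. "The series", "measured", "known", "first", "only" and "open" are said of these compounds alone.

The three measured compounds are:
Compound 1, `COC1(c2ccccc2)Oc2ccccc2C(=O)C1(O)O`: 19 ug/mL
Compound 2, `O=c1cc(-c2ccc(O)cc2)oc2c(O)c(O)c(O)cc12`: 22 ug/mL
Compound 3, `COc1ccc2c(c1)OC(OC)(c1ccccc1)C(O)(O)C2=O`: 20 ug/mL

In a functional assay on KB cells (Homo sapiens) for cytotoxicity (on this read-out lower numbers stand for an effect already at smaller amounts and higher numbers for an effect only at larger amounts of compound), compound 3 holds the second highest of the three numbers. Its nearest neighbour is compound 1, whose value sits within the scatter of that of compound 3, and compound 2, the furthest, is likewise within the scatter. The three values therefore cannot be put in any order.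

Compound 4, `COc1ccc(C2(OC)Oc3cc(OC)ccc3C(=O)C2(O)O)cc1`, differs from compound 3 in one place: methoxy in place of hydrogen on an aromatic carbon. Cut one bond further out, the change reads as phenyl to 4-methoxyphenyl. Among the measured compounds shown here, only one measured step bears on this change, the introduction of a methoxy on an aromatic carbon of the core in going from compound 1 to compound 3, and that step gave a 1.1-fold higher number from compound 1 to compound 3 (0.02 log units; within the scatter). For the measured compounds named here, that methoxy sits on a different ring than the one now changed, so the parallel is loose; still, it is the only guide, and it points to no change beyond the scatter. Compound 4 is therefore expected to show no change at the digits printed from compound 3 to compound 4 (within the scatter). The estimate for compound 4 is 20 ug/mL, in the range 10 ug/mL to 40 ug/mL.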

Compound 4, concentration for half-maximal effect: 2.8 ug/mL
Beside the measured number, compound 4's estimate is 7.1-fold (0.85 log units) above it; measured number outside the range, below it.
By their numbers in this assay, from the lowest: compound 4; then compounds 1, 3 and 2 (each within the scatter of the next).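

In this assay, among the compounds shown here, the step of a 7.1-fold lower number from compound 3 to compound 4 (0.85 log units; beyond the scatter) is the first one to lie beyond the scatter, and it shows that this carbon of the phenyl ring, para to a large group, is a place where the read-out responds to substitution. The earlier step, a 1.1-fold higher number from compound 1 to compound 3 (0.02 log units; within the scatter), put the same methoxy-for-hydrogen exchange on a different ring and gave no change that could be told from the scatter, so the outcome of this exchange depends on where it is made, at least across these two steps. Nothing shown here gives a measured reason for the difference between the two places.

On these data alone, what remains open is whether the lower number belongs to methoxy itself, or whether a hydroxyl, an amine or a longer chain such as butoxy on the same carbon would give a similar number. As far as these compounds go, it is also open whether phenyl to 4-methoxyphenyl would give a similar step on the core of compound 1, which lacks the methoxy that compound 3 carries on the other ring.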